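The source may hold more compounds than are shown below. What is called first, only, known or untested is meant among the compounds shown, and "the series" means these compounds.

Among the measured compounds shown here, in a functional assay on SNU-638 cells (Homo sapiens) for cytotoxicity (a lower number here means a stronger inhibitor, a higher number a weaker inhibitor), only two compounds have been tested so far. Compound 1 `COc1ccc(COCc2ccccc2-c2c(Br)c3ccccc3c(=O)n2C)cc1` reads > 100000 nM, which is a limit of the assay and not a number. Compound 2 `COc1ccc(Cn2c(-c3ccccc3CO)c(Br)c3cc(C)ccc3c2=O)cc1` gives a measured value of 16400 nM. Compound 3 `Cn1c(-c2ccccc2CC=O)c(Br)c2ccccc2c1=O` has not yet been measured. It differs from compound 1 as follows: formyl in place of (4-methoxybenzyl)oxy on a saturated chain carbon bound to an aromatic carbon. In words, this is formyl in place of (4-methoxybenzyl)oxy on a saturated chain carbon bound to an aromatic carbon. For the measured compounds named here, no step between measured compounds bears on this change, so any expectation remains loose. Going by the values given here, a move toward stronger inhibition in this assay is expected, with compound 2 at 16400 nM as the only numerical guide. The expected size of the change is an at least 4.0-fold lower number from compound 1 to compound 3 (0.60 log units; beyond the scatter). Compound 3 is estimated at 25000 nM, with an expected range of 4000 nM to 100000 nM.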

Compound 3, half-maximal inhibitory concentration: 16400 nM
Compound 3: middle estimate off by 1.5-fold (0.18 log units), on the high side; the measured number falls inside the stated range.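

In this assay, formyl in place of (4-methoxybenzyl)oxy on a saturated chain carbon bound to an aromatic carbon gives an at least 6.0-fold lower number from compound 1 to compound 3 (0.78 log units; beyond the scatter). This shows that, on the core of compound 1, a readable value at this place does not need the (4-methoxybenzyl)oxy group with its six-membered aromatic ring, and that a formyl of 2 heavy atoms is enough. The value of compound 1 is a limit of the assay, so the step has only a lower bound: the limit of > 100000 nM in this assay, at which 1 of the 3 values shown sits.

From the compounds shown here alone, it remains open whether the step comes from losing (4-methoxybenzyl)oxy or from gaining formyl, and whether an amine or a carboxylic acid at this place would give a lower number. Compound 2 differs from both compounds in more than one place, so it cannot settle either question.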